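The source may report more compounds than this note shows. Statements on the series, on what has been measured and on what is new or still open speak of the compounds shown alone.

Measured so far in a functional assay on HT-29 cells (Homo sapiens) for inhibition, read by flow cytometry, tested at 10 uM; on this read-out higher numbers stand for more inhibition at the one concentration tested (going by the name of the read-out) and lower numbers for less inhibition:
- compound 1 `O=C(CSc1nc2ccccc2[nH]1)c1ccc(Br)cc1`: "not active" (no number reported)
- compound 2 `COc1ccccc1C(=O)CSc1nc2ccccc2[nH]1`: 34.9%
- compound 3 `COc1ccc(C(=O)CSc2nc3ccccc3[nH]2)cc1O`: 49.7%

Compound 1 carries no number in this assay, only the note that it is not active, so it cannot be placed against compound 2 or compound 3; of those two, compound 3 shows the higher reading, compound 2 the lower. Within the data shown here, no pair of measured compounds differs in one place, so no step size has been read.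

Compound 4 `O=C(CSc1nc2ccccc2[nH]1)c1ccc([N+](=O)[O-])cc1` is the next member. Against compound 1 the change is nitro in place of bromo on an aromatic carbon. Among the measured compounds shown here, since compound 1 has no number, a step to compound 4 cannot be computed, and with only three compounds behind it no clear direction is supported; a small shift, if any, toward measurable inhibition is expected, possibly with only a limit reported again. For compound 4 the estimate in this assay is 20%, expected to fall between 0% and 45%.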

Compound 4, a percentage reported as inhibition, at one concentration (the size of the read-out at that concentration, not a potency): "not active" (no number reported)
No number was reported for compound 4; there is nothing to compare the estimate with.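

No step can be read between compound 1 and compound 4, since neither carries a number. The compounds shown leave open whether nitro in place of bromo shifts inhibition at all. No supporting evidence bears on this result.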